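Removing the Second Methoxy From the Dimethoxybenzyl Sulfonamide

A few compounds are considered here, and "the series" means these few. Any claim that something is new, unique, unknown or untested is made for them only; others in the source may bear on it.

Three members of the series have been measured in a functional assay on PANC-1 cells (Homo sapiens) for inhibition, read by MTT assay, with a stated time of 72 h; a higher number here means a weaker inhibitor of growth, a lower number a stronger inhibitor of growth. Compound 1 `O=S(=O)(NCCCCNCc1ccc(Br)cc1)c1cc(C(F)(F)F)cc(C(F)(F)F)c1` gives 2200 nM. Compound 2 `COc1ccc(CNCCCNS(=O)(=O)c2cc(C(F)(F)F)cc(C(F)(F)F)c2)cc1OC` gives 18000 nM, and compound 3 `COc1ccc(CNCCCNS(=O)(=O)c2cc(C(F)(F)F)cc(C(F)(F)F)c2)cc1` gives 11000 nM. Compound 2 thus has the highest of the three numbers; its gap to compound 3 is within the scatter, while its gap to compound 1 is beyond it. Among the compounds with values here, the one larger step in the set, a 5.0-fold higher number from compound 1 to compound 3 (0.70 log units; beyond the scatter), concerns the bromobenzyl-to-methoxybenzyl exchange and does not touch the change examined here.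

Compound 4 `COc1cccc(CNCCCNS(=O)(=O)c2cc(C(F)(F)F)cc(C(F)(F)F)c2)c1` has not been measured. Relative to compound 2 the change is hydrogen in place of methoxy on an aromatic carbon. The directly comparable step is a 1.6-fold lower number from compound 2 to compound 3 (0.21 log units; within the scatter), where the other methoxy of the same ring was removed and the number moved only slightly downward. On that basis the removal of the remaining ring methoxy is expected to give a change of similar size at most, downward if anything, in this assay: the estimated step is a 1.5-fold lower number from compound 2 to compound 4 (0.18 log units; within the scatter), which is within the scatter. Compound 4 is therefore estimated at 12000 nM in this assay, with a range from 5500 nM to 28000 nM. Within the data shown here, only one prior step informs this, so the range is kept wide.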

Compound 4, concentration for 50% growth inhibition: 10000 nM
Compound 4: middle estimate off by 1.2-fold (0.08 log units), on the high side, within the range that was stated.
By their numbers in this assay, from the lowest: compound 1; then compounds 4, 3 and 2 (each within the scatter of the next).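

In this assay, taking away the other methoxy of the 3,4-dimethoxybenzyl group, so that 3-methoxybenzyl remains, gives a 1.8-fold lower number from compound 2 to compound 4 (0.26 log units; within the scatter), so both single removals from the dimethoxy ring are now seen to stay within the scatter, where earlier only one had been read. The two monomethoxy compounds cannot be told apart in this assay, with 3-methoxyphenyl in place of 4-methoxyphenyl giving a 1.1-fold lower number from compound 3 to compound 4 (0.04 log units; within the scatter), so no preference for either methoxy placement appears in these numbers. Within the data shown here, the only step of this set beyond the scatter remains the one involving the bromobenzyl compound, a 4.5-fold higher number from compound 1 to compound 4 (0.66 log units; beyond the scatter), and since that exchange alters the benzyl group and the chain together, it cannot be credited to either part alone.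

Open, going by these compounds, are the plain benzyl group carrying neither methoxy, a hydroxyl or an amine on the ring in place of methoxy, and a 4-bromobenzyl group on the chain of compound 4, which would separate the two parts of that larger step. No measurement at hand accounts for any of these steps.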